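The source may hold more compounds than are shown below. What is called first, only, known or untested is meant among the compounds shown, and "the series" means these compounds.

Measured compounds:
Compound 1 `COc1ccccc1C(=O)Nc1cccc(NC(=O)c2cc(Cl)cc(Cl)c2)c1`: in an in vitro functional assay on HEK293-A cells for antagonist activity at metabotropic glutamate receptor 5 (Rattus norvegicus), read by calcium flux (on this read-out lower numbers stand for stronger inhibition and higher numbers for weaker inhibition), compound 1 gives > 30000 nM, which is a limit of the assay and not a number.
Compound 2 `COc1ccccc1C(=O)Nc1cccc(NC(=O)C2CCCCC2)c1`: in this assay compound 2 gives > 30000 nM, likewise a limit of the assay and not a number.

Among the compounds with values here, compound 2 therefore stands at the limit, with no number of its own, and the only other value shown is a limit as well, so that both sit at the limit of > 30000 nM in this assay, at which 2 of the 2 values shown sit. The step that the two limits leave unreadable from compound 1 to compound 2 is one that the two limits leave unreadable in size and direction.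

Compound 3 `COCC(=O)Nc1cccc(NC(=O)c2ccccc2OC)c1` differs from compound 2 by methoxymethyl in place of cyclohexyl on a carbonyl carbon. Within the data shown here, the one measured step concerns the same carbonyl carbon, but since it cannot be read, it gives neither a size nor a direction for the step in this assay. Because both values shown sit at the limit of > 30000 nM in this assay, at which 2 of the 2 values shown sit, compound 3 is expected to remain at the limit too, the estimated step being a step that the limit leaves unreadable from compound 2 to compound 3. Compound 3 is thus estimated at 40000 nM, with a range from 10000 nM to 150000 nM, and a limit rather than a number is the most likely outcome.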

Compound 3, half-maximal inhibitory concentration: > 30000 nM
Compound 3 gave a limit, no number; the forecaster's own chance of this, stated with the estimate: 85%; the middle value does not contradict the limit.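

Within the data shown here, no step from compound 1 or compound 2 to compound 3 can be read, in size or in direction, in this assay, since all three compounds give a limit of the assay and not a number: the limit of > 30000 nM in this assay, at which 3 of the 3 values shown sit. The compounds shown leave open which group on the carbonyl carbon, if any, would give a measurable inhibition.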